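This account rests on a few compounds, and the source may have more. Where it says the series, first, only, none or still open, it means among the compounds named here.

In a functional assay on NCI-H1650 cells (Homo sapiens) for cytotoxicity, read by MTT assay, with a stated time of 48 h (a higher number here means a weaker inhibitor, a lower number a stronger inhibitor), compound 3 `CN(C)CCCNc1ccnc2cc(OCc3ccc(F)cc3)ccc12` gives 940 nM, the second highest of the three numbers on hand. Compound 2 `CCCCCCOc1ccc2c(NCCN(C)C)ccnc2c1` gives 930 nM, which sits within the scatter of compound 3. Going by the values given here, compound 1 `C=CCOc1ccc2c(NCCCN(C)C)ccnc2c1` gives 3120 nM; the one step between compounds differing in a single place is a 3.3-fold lower number from compound 1 to compound 3 (0.52 log units; beyond the scatter), 4-fluorophenyl in place of vinyl on the chain carbon bound to the aromatic oxygen. Compound 4 `CN(C)CCNc1ccnc2cc(OCc3ccc(F)cc3)ccc12` differs from compound 3 by dimethylamino in place of (dimethylamino)methyl on a saturated chain carbon, two bonds along the chain from a nitrogen on an aromatic ring. Among the compounds with values here, no measured step isolates this change: compound 2 carries the shorter chain and compound 3 the longer, but the two also differ in the group on the oxygen, and their two values lie within the scatter of each other. The change is therefore expected to give a 1.0-fold higher number from compound 3 to compound 4 (0.00 log units; within the scatter), nothing beyond the scatter. Compound 4 is estimated at 950 nM, with a range of 450 nM to 2000 nM.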

Compound 4, half-maximal inhibitory concentration: 780 nM
Compound 4: middle estimate off by 1.2-fold (0.09 log units), on the high side; low and high end bracket the measured number.
By their numbers in this assay, from the lowest: compounds 4, 2 and 3 (each within the scatter of the next); then compound 1.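

Working directly on the amine chain for the first time, a 1.2-fold lower number from compound 3 to compound 4 (0.08 log units; within the scatter), which puts 2-(dimethylamino)ethyl and 3-(dimethylamino)propyl within the scatter when the group on the oxygen is held constant. On the shorter chain, a 1.2-fold lower number from compound 2 to compound 4 (0.08 log units; within the scatter), so 4-fluorophenyl and pentyl on the carbon bound to the oxygen also stay within the scatter. No measurement offered here gives a reason for either result.

Going by these compounds, whether a 4-(dimethylamino)butyl chain or a piperidine in place of dimethylamino would keep these numbers remains open. Vinyl on the shorter chain is also open.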